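Ester series: the step from compound 3 to compound 4

A few compounds are considered here, and "the series" means these few. Any claim that something is new, unique, unknown or untested is made for them only; others in the source may bear on it.

Measured in an ADME assay on a cell-free system (plasma, Homo sapiens) for metabolic stability, at 37 degrees C; a higher number here means that the compound lasts longer, a lower number that the compound disappears faster:
- compound 1 `CCC/N=C1\S/C(=C\c2ccc(C(=O)O)cc2)C(=O)N1c1ccccc1O`: > 3 h
- compound 2 `CCC/N=C1\S/C(=C\c2ccc(C(=O)OCCCO)cc2)C(=O)N1c1ccccc1O`: > 3 h
- compound 3 `CCC/N=C1\S/C(=C\c2ccc(C(=O)OCC(O)CO)cc2)C(=O)N1c1ccccc1O`: > 3 h

Each of these entries is a limit and not a number. Compound 3 gives > 3 h, which is a limit. For the measured compounds named here, the series so far sits at a single place: the limit of > 3 h in this assay, at which 3 of the 3 values shown sit.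

Compound 4 `CCC/N=C1\S/C(=C\c2ccc(C(=O)OCc3oc(=O)oc3C)cc2)C(=O)N1c1ccccc1O` carries a new group: a group of 7 heavy atoms (4 carbon, 3 oxygen; one five-membered aromatic ring with 2 hetero atoms) in place of a group of 4 heavy atoms (2 carbon, 2 oxygen; no ring), on a saturated chain carbon bound to an oxygen next to a carbonyl group. The entering group holds one five-membered aromatic ring with 2 hetero atoms, and the leaving group, 1,2-dihydroxyethyl, has no ring.

Going by the values given here, three measured steps bear on this change: a step that the two limits leave unreadable from compound 1 to compound 2, a step that the two limits leave unreadable from compound 1 to compound 3 and a step that the two limits leave unreadable from compound 2 to compound 3. None of them has a readable size, and in none of them does a ring enter, so they set no measure for this change. The direction expected in this assay is toward a shorter half-life, a judgment resting on the structural change alone and held with low confidence. The estimated move is an at least 4.2-fold lower number from compound 3 to compound 4 (0.63 log units; beyond the scatter). For compound 4 the estimate is 0.7 h, with an expected range of 0.1 h to 3 h.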

Compound 4, half-life: 0.15 h
Compound 4: the middle estimate sits 4.7-fold (0.67 log units) above what was measured; low and high end bracket the measured number.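

For the compounds shown here, compound 4 holds the only number that is not a limit in this assay, and it shows that the group on a saturated chain carbon bound to an oxygen next to a carbonyl group can move the half-life by a large margin: the change reads as an at least 20-fold lower number from compound 3 to compound 4 (1.30 log units; beyond the scatter), as an at least 20-fold lower number from compound 2 to compound 4 (1.30 log units; beyond the scatter) and as an at least 20-fold lower number from compound 1 to compound 4 (1.30 log units; beyond the scatter). The steps among compound 1, compound 2 and compound 3 cannot be read, and these three compounds stay together at one place: the limit of > 3 h in this assay, at which 3 of the 4 values shown sit. Only compound 4 carries a five-membered aromatic ring with 2 hetero atoms in this group, so the ring and the shorter half-life are seen together just once.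

Open, on these data alone, is which part of the entering group goes with the change, a question that a methyl ester or a benzyl ester on the same core would bear on. Also open, as far as these compounds go, are how far apart compound 1, compound 2 and compound 3 really lie, and whether the carboxylic acid of compound 1 appears in this assay as compound 4 disappears.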